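Aryl sulfonamide series: weak growth inhibition at the anilide ring

The compounds below may be only part of what the source reports. "The series", "measured", "known", "first", "only" and "open" are said of these compounds alone.

Measured so far in a functional assay on cells (leukaemia cell line, Homo sapiens) for inhibition, read by sulforhodamine B assay, with a stated time of 48 h; a higher number here means a weaker inhibitor of growth, a lower number a stronger inhibitor of growth:
compound 1 `O=S(=O)(Nc1ccc(Br)c(Cl)c1)c1ccc(-c2cnc(C3CC3)o2)cc1` gives 70300 nM.
compound 2 `O=S(=O)(Nc1cc(Cl)ccc1Cl)c1ccc(-c2cnc(C3CC3)o2)cc1` gives > 100000 nM, which is a limit of this assay and not a number.

For the measured compounds named here, compound 1 holds the only numerical value shown; compound 2 reaches only (the limit of > 100000 nM in this assay, at which 1 of the 2 values shown sits). Going by the values given here, the step of an at least 1.4-fold higher number from compound 1 to compound 2 (0.15 log units; that floor lies within the scatter) is the single measured change at the sulfonamide nitrogen. Compound 3 `Cc1cc(Cl)cc(NS(=O)(=O)c2ccc(-c3cnc(C4CC4)o3)cc2)c1` carries 3-chloro-5-methylphenyl in place of 4-bromo-3-chlorophenyl on a sulfonamide nitrogen. Among the compounds with values here, with only that step as guidance, no change beyond the scatter is expected in this assay, though a limit remains possible. Compound 3 is estimated at 80000 nM (range 30000 nM to 200000 nM), an expected step of a 1.1-fold higher number from compound 1 to compound 3 (0.06 log units; within the scatter).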

Compound 3, concentration for total growth inhibition: 7040 nM
For compound 3 the middle estimate is 11-fold (1.06 log units) above the measured one; measured number outside the range, below it.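

The aryl group on the sulfonamide nitrogen can shift growth inhibition in this assay beyond the scatter: 3-chloro-5-methylphenyl in place of 4-bromo-3-chlorophenyl gives a 10-fold lower number from compound 1 to compound 3 (1.00 log units; beyond the scatter). Against 2,5-dichlorophenyl, the same group gives an at least 14-fold lower number from compound 2 to compound 3 (1.15 log units; beyond the scatter), and this size is only a floor. Compound 2 stands at a limit and not a number: the limit of > 100000 nM in this assay, at which 1 of the 3 values shown sits.

The compounds shown do not separate the entry of the methyl group from the loss of bromine. On these data alone, how an amine or a methoxy group on this ring would read remains open.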